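The source may report more compounds than this note shows. Statements on the series, on what has been measured and on what is new or still open speak of the compounds shown alone.

Working notes on the series in a functional assay (strain AB) with Danio rerio as the target, read by microscopy, with a stated time of 1 h; on this read-out higher numbers stand for an effect only at larger amounts of compound and lower numbers for an effect already at smaller amounts. Compound 1 `NC(=O)c1c(NC(=O)Nc2ccc(Cl)cc2)sc2c1CCN(C1CCOCC1)C2` gives 2830 nM, the higher of the two numbers obtained so far. Compound 3 `C[N+]1(CC2CCC2)CCc2c(sc(NC(=O)Nc3ccc(Cl)cc3)c2C(N)=O)C1` gives 210 nM, a lower number that lies beyond the scatter. Compound 2 `CCN1CCc2c(sc(N)c2C(N)=O)C1` yields only a limit in this assay, > 25000 nM. That limit is the limit of > 25000 nM in this assay, at which 1 of the 3 values shown sits.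

Compound 4 `NC(=O)c1c(NC(=O)Nc2ccc(Cl)cc2)sc2c1CCN(CC1CCCC1)C2` has not been measured. It differs from compound 1 by cyclopentylmethyl in place of oxan-4-yl on an amine nitrogen in a ring. With compound 3 standing at 210 nM, the step of a 2.6-fold lower number from compound 1 to compound 4 (0.41 log units; beyond the scatter) is expected to run toward a lower number, modestly beyond the scatter but short of what compound 3 shows. Compound 4 is estimated at 1100 nM, with a range from 400 nM to 3000 nM.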

Compound 4, half-maximal effective concentration: 1830 nM
For compound 4 the middle estimate is 1.7-fold (0.22 log units) below the measured one; measured number inside the range.
By their numbers in this assay, from the lowest: compound 3; then compounds 4 and 1 (each within the scatter of the next). At a limit, above all of these: compound 2.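

In this assay the change on this amine nitrogen in a ring gives a 1.5-fold lower number from compound 1 to compound 4 (0.19 log units; within the scatter) and so removes the ring oxygen and its hydrogen-bond acceptor with no change that can be told from the scatter. At this position, oxan-4-yl and the all-carbon cyclopentylmethyl, with the same count of heavy atoms, cannot be told apart. Nothing at hand accounts for this step.

The compounds shown leave open what a carboxylic acid or a longer alkyl chain on this same nitrogen would give in this assay.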